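Ethyl Ester Analogue Expected to Match Its Long-Lived Parents

The source may hold more compounds than are shown below. What is called first, only, known or untested is meant among the compounds shown, and "the series" means these compounds.

compound 1 `COC(=O)[C@@H](N)CSNC(=O)[C@@H](CCC(F)(F)F)N(Cc1ccc(-c2ncon2)cc1F)S(=O)(=O)c1ccc(Cl)cc1`: > 500 h
compound 2 `N#CCCSNC(=O)[C@@H](CCC(F)(F)F)N(Cc1ccc(-c2ncon2)cc1F)S(=O)(=O)c1ccc(Cl)cc1`: > 500 h

In a physicochemical assay for pharmacokinetics, at pH 1, tested at 100 ug/mL (a higher number here means that the compound lasts longer, a lower number that the compound disappears faster), compound 1 gives > 500 h, which is a limit of the assay and not a number. In this assay compound 2 likewise gives > 500 h, again a limit. The step that the two limits leave unreadable from compound 1 to compound 2 is therefore unreadable in size. Compound 3 `CCOC(=O)[C@@H](N)CSNC(=O)[C@@H](CCC(F)(F)F)N(Cc1ccc(-c2ncon2)cc1F)S(=O)(=O)c1ccc(Cl)cc1` differs from compound 2 by amino(ethoxycarbonyl)methyl in place of cyanomethyl on a saturated chain carbon bound to a sulfur. Among the measured compounds shown here, no measured step gives a readable size for such a change; what both measured compounds share is the limit of > 500 h in this assay, at which 2 of the 2 values shown sit. Compound 3 is therefore expected to reach that limit too, with an expected step that the limit leaves unreadable from compound 2 to compound 3 not readable beyond the scatter. The estimate for compound 3 is 1000 h, from 300 h to 5000 h.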

Compound 3, half-life: > 500 h
Compound 3 ended at the assay's limit; the forecaster's own chance of this, stated with the estimate: 90%; the middle value lies beyond the limit too.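

No step among compound 1, compound 2 and compound 3 can be read in size, as all three share a single result that is a limit and not a number: the limit of > 500 h in this assay, at which 3 of the 3 values shown sit.

How long each of these compounds actually lasts in this assay, and whether their differing groups change that, remains open.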